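The compounds below may be only part of what the source reports. "The series", "measured", "known", "first", "only" and "open" are said of these compounds alone.

Measured so far in a functional assay on HCT-116 cells (Homo sapiens) for inhibition, read by MTT assay, with a stated time of 72 h; on this read-out lower numbers stand for stronger inhibition of growth and higher numbers for weaker inhibition of growth:
compound 1, `O[C@H](COCCOC[C@@H](O)Cc1cn(Cc2ccc3ccccc3c2)nn1)Cc1ccc(-c2ccccc2)cc1`: 8600 nM
compound 2, `O[C@H](COCCOC[C@@H](O)Cc1cn(Cc2ccc(Oc3ccccc3)cc2)nn1)Cc1ccc(-c2ccccc2)cc1`: 3400 nM

Compound 1 holds the higher of the two numbers; the value of compound 2 sits lower, and the gap between them exceeds the usual scatter. Both compounds share the same core and differ only in the group carried on the aromatic nitrogen, so the two numbers are all that can be said of that pair.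

Compound 3, `O[C@H](COCCOC[C@@H](O)Cc1cn(-c2cccs2)nn1)Cc1ccc(-c2ccccc2)cc1`, has not been measured. Relative to compound 1 the change is thiophen-2-yl in place of (naphthalen-2-yl)methyl on an aromatic nitrogen. Within the data shown here, no measured pair isolates this kind of change, so the expected step rests on the structural change alone. The group that enters is much smaller than the one that leaves, and the arrangement on the nitrogen is altered; a move toward weaker inhibition is expected, of a size a 1.7-fold higher number from compound 1 to compound 3 (0.24 log units; within the scatter) in this assay. For compound 3 the estimated value is 15000 nM, with a range from 5000 nM to 45000 nM.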

Compound 3, concentration for 50% growth inhibition: 33400 nM
For compound 3 the middle estimate is 2.2-fold (0.35 log units) below the measured one; measured number inside the range.
By their numbers in this assay, from the lowest: compound 2; then compound 1; then compound 3.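

In this assay, thiophen-2-yl in place of (naphthalen-2-yl)methyl on the aromatic nitrogen gives a 3.9-fold higher number from compound 1 to compound 3 (0.59 log units; beyond the scatter), so this position does respond to the group it carries, and here the weaker inhibition comes with the smaller group. The change replaces two fused six-membered aromatic rings with one five-membered ring and also removes the methyl link to the nitrogen, so this single step cannot assign the shift to either feature. Nothing at hand accounts for the step.

Open, on these data alone, is whether thiophen-2-ylmethyl or plain benzyl on this nitrogen, with the methyl link kept, would separate ring from link. Also open, as far as these compounds go, is how an amine or a carboxylic acid on this group would read in this assay.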